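Working notes: amide aryl change from compound 3 to compound 4

This account rests on a few compounds, and the source may have more. Where it says the series, first, only, none or still open, it means among the compounds named here.

Measured so far in a functional assay on A549 cells (Homo sapiens) for antiproliferative activity, read by CCK-8 assay, with a stated time of 72 h; on this read-out higher numbers stand for weaker inhibition and lower numbers for stronger inhibition:
- compound 1 `O=C(Nc1cccc(-c2oc3cc(-c4ccc(F)cc4)ccc3c(=O)c2O)c1)c1ccc(F)cc1` gives 6930 nM
- compound 2 `COc1cccc(C(=O)Nc2cccc(-c3oc4cc(-c5ccc(F)cc5)ccc4c(=O)c3O)c2)c1` gives 10800 nM
- compound 3 `O=C(Nc1cccc(-c2oc3cc(-c4ccc(F)cc4)ccc3c(=O)c2O)c1)c1cccc(F)c1` gives 15400 nM

Compound 3 holds the highest number of the three. The step of a 2.2-fold higher number from compound 1 to compound 3 (0.35 log units; beyond the scatter) lies beyond the scatter and is modest in size; the step of a 1.4-fold higher number from compound 2 to compound 3 (0.15 log units; within the scatter) lies within the scatter, so compound 2 and compound 3 cannot be told apart on these numbers.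

Compound 4 `O=C(Nc1cccc(-c2oc3cc(-c4ccc(F)cc4)ccc3c(=O)c2O)c1)c1ccc(Br)cc1F` differs from compound 3 in one place: 4-bromo-2-fluorophenyl in place of 3-fluorophenyl on a carbonyl carbon. Going by the values given here, no measured step covers this change directly, as none of the measured compounds carries a bromine or a fluorine-plus-second-substituent pattern on the aryl attached to the carbonyl. The steps of a 1.6-fold higher number from compound 1 to compound 2 (0.19 log units; within the scatter) and a 2.2-fold higher number from compound 1 to compound 3 (0.35 log units; beyond the scatter) bear on it only loosely: each shows that exchanging or relocating a single substituent on that aryl shifts the number by small amounts, at or just past the edge of the scatter, in either direction. On that basis the step from compound 3 to compound 4 is expected to be small and of uncertain direction, a 1.5-fold lower number from compound 3 to compound 4 (0.19 log units; within the scatter).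

Compound 4 is estimated at 10000 nM, with a range from 3500 nM to 30000 nM.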

Compound 4, half-maximal inhibitory concentration: 46100 nM
Estimate against measurement, compound 4: 4.6-fold (0.66 log units) below; the measured number lies above the stated range.
By their numbers in this assay, from the lowest: compounds 1, 2 and 3 (each within the scatter of the next, the first and the last beyond it); then compound 4.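

In this assay the aryl on the carbonyl carbon proves able to move the number well past the small shifts seen among the first three compounds: 4-bromo-2-fluorophenyl gives a higher number against each earlier aryl (a 3.0-fold higher number from compound 3 to compound 4 (0.48 log units; beyond the scatter); a 4.3-fold higher number from compound 2 to compound 4 (0.63 log units; beyond the scatter); a 6.7-fold higher number from compound 1 to compound 4 (0.82 log units; beyond the scatter)), and all three steps lie beyond the scatter. This position is therefore not indifferent to the substitution of that aryl, and among the four compounds the change to 4-bromo-2-fluorophenyl runs toward weaker inhibition, leaving compound 4 with the highest number of the series. No measurement in hand accounts for this rise.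

On these data alone, what the bromine contributes apart from the fluorine of 4-bromo-2-fluorophenyl stays open on these four compounds, since both differ from the earlier aryls at once. Also open, as far as these compounds go, is how the number responds when the aryl on the carbonyl carbon carries an amine or a carboxylic acid, or when a longer alkyl chain takes its place.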